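A few compounds are considered here, and "the series" means these few. Any claim that something is new, unique, unknown or untested is made for them only; others in the source may bear on it.

Of the compounds shown here, three have been measured in a functional assay on MCF7 cells (Homo sapiens) for inhibition, read by sulforhodamine B assay, with a stated time of 48 h (on this read-out higher numbers stand for weaker inhibition of growth and lower numbers for stronger inhibition of growth), and a fourth, compound 4, has yet to be measured. Compound 1, `O=C1C=COC(/C=C/c2ccc(C(F)(F)F)cc2)C1`, carries a trifluoromethyl on its aromatic ring, and in this assay compound 1 gives 41.2 uM. Compound 2, `COc1ccc(/C=C/C2CC(=O)C=CO2)cc1`, keeps the same core and differs from compound 1 by methoxy in place of trifluoromethyl on an aromatic carbon. In this assay compound 2 gives 156 uM, so this change produced a 3.8-fold higher number from compound 1 to compound 2 (0.58 log units; beyond the scatter). Compound 3, `O=C1C=CCC(/C=C/c2ccc(C(F)(F)F)cc2)N1`, is built on a different core from compound 1; the difference between the two cores is not broken down here. In this assay compound 3 gives 150 uM. The numbers for compound 3 and compound 2 lie within the scatter of each other, whereas compound 1 sits beyond the scatter below both of them. Compound 4, `COc1ccc(/C=C/C2CC=CC(=O)N2)cc1`, stands to compound 3 as compound 2 stands to compound 1: the change is methoxy in place of trifluoromethyl on an aromatic carbon, the same change made at the same place. Because the first occurrence of this change gave a 3.8-fold higher number from compound 1 to compound 2 (0.58 log units; beyond the scatter), the second occurrence is expected to make a step of similar size, a 3.0-fold higher number from compound 3 to compound 4 (0.48 log units; beyond the scatter). Since compound 3 already gives 150 uM, compound 4 is expected to come out weaker still. The estimate for compound 4 is 450 uM, with a range from 150 uM to 1200 uM.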

Compound 4, concentration for growth inhibition (reported as GI): > 1090 uM
Compound 4: no number, only a limit; the forecaster's own chance of this, stated with the estimate: 40%; middle value at least 2.4-fold (0.38 log units) from the limit.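

For compound 4 the result is a limit of the assay and not an exact number: the limit of > 1090 uM in this assay, at which 1 of the 4 values shown sits. In this assay, putting methoxy in place of trifluoromethyl on an aromatic carbon gives an at least 7.2-fold higher number from compound 3 to compound 4 (0.86 log units; beyond the scatter), so the change moves the number the same way on the second core as on the core of compound 1, towards weaker inhibition of growth. This shows that the direction of the change carries over between these two cores, but it does not show whether the size of the step carries over as well, and two cores are too few to make a general rule for the series: the same change on two cores in this assay, a 3.8-fold higher number (0.58 log units; beyond the scatter) from compound 1 to compound 2 and an at least 7.2-fold higher number (0.86 log units; beyond the scatter) from compound 3 to compound 4; the limit leaves it open whether they differ.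

The compounds shown carry only trifluoromethyl or methoxy at this place on the ring, so it remains open how another group there, such as an amine, a carboxylic acid or a longer chain, would behave on either core. As far as these compounds go, it also remains open where compound 4 would fall if given an exact number, and whether the same change would act in the same direction on a third core.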